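The source may hold more compounds than are shown below. What is called first, only, known or untested is meant among the compounds shown, and "the series" means these compounds.

Compound 1 `Cc1cccc(Nc2nc(N)nc(COc3ccc4c(C)cc(=O)oc4c3)n2)c1` is the reference point of this small set. Among the compounds with values here, in an assay on COS-7 cells for agonist activity at Free fatty acid receptor 1 (Homo sapiens), read by scintillation counting and inositol phosphate accumulation, with a stated time of 90 min (on this read-out higher numbers stand for an effect only at larger amounts of compound and lower numbers for an effect already at smaller amounts), compound 1 gives 1780 nM, the only number in hand, since for compound 2 `Cc1cc(=O)oc2cc(OCc3nc(N)nc(Nc4ccc(O)cc4)n3)ccc12` the same assay records "not determined" (no result reported). Compound 3 `Cc1cc(=O)oc2cc(OCc3nc(N)nc(NCc4ccc(F)cc4)n3)ccc12` differs from compound 1 in one place: 4-fluorobenzyl in place of 3-methylphenyl on a nitrogen on an aromatic ring. Within the data shown here, no measured pair shows how this kind of change plays out here, so the direction is open; the step is expected to be modest, a 1.4-fold higher number from compound 1 to compound 3 (0.15 log units; within the scatter), leaning towards an effect only at somewhat larger amounts. Compound 3 is accordingly estimated at 2500 nM, with a range from 700 nM to 9000 nM.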

Compound 3, half-maximal effective concentration: 7820 nM
Compound 3: middle estimate off by 3.1-fold (0.50 log units), on the low side, within the range that was stated.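

The change at this nitrogen is not neutral: in this assay the swap of 3-methylphenyl for 4-fluorobenzyl gives a 4.4-fold higher number from compound 1 to compound 3 (0.64 log units; beyond the scatter) and so moves the result beyond the scatter, towards an effect only at larger amounts of compound. This single step changes both the aryl substituent and the link to the nitrogen, and the two cannot be told apart. Nothing available explains the shift.

From the compounds shown here alone, it remains open whether the step belongs to the extra carbon of the benzyl or to the fluorine. Going by these compounds, how an unsubstituted benzyl, a plain phenyl or a phenyl bearing a carboxylic acid would read at this nitrogen also remains open.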